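Methoxy on the chain of compound 3

A few compounds are considered here, and "the series" means these few. Any claim that something is new, unique, unknown or untested is made for them only; others in the source may bear on it.

In a physicochemical assay for solubility, in phosphate buffer, measured as kinetic solubility, at pH 7.4, tested at 250 uM (on this read-out higher numbers stand for higher solubility and lower numbers for lower solubility), compound 1 `CCCCCCCCNc1ccc([N+](=O)[O-])cc1S(N)(=O)=O` gives < 1000 nM, which is a limit of the assay and not a number. Compound 2 `CCCCCCNc1ccc([N+](=O)[O-])cc1S(=O)(=O)N(C)C` gives 1000 nM, and compound 3 `CCCCCCNc1ccc(C(=O)O)cc1S(=O)(=O)N(C)C` gives 243000 nM, the highest of the two numbers. The next change leads to compound 4 `COCCCCCCNc1ccc(C(=O)O)cc1S(=O)(=O)N(C)C`: methoxy in place of hydrogen on a saturated chain carbon, six bonds along the chain from a nitrogen on an aromatic ring.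

For the measured compounds named here, only one measured step is available, a 240-fold higher number from compound 2 to compound 3 (2.39 log units; beyond the scatter). That large step, beyond the scatter, put carboxy in place of nitro on an aromatic carbon, so it bears on the new change only indirectly and sets no size for it. Compound 3 keeps that carboxy, and at 243000 nM it already lies close to the tested concentration. No step beyond the scatter is therefore expected, in either direction. The expected step is a 1.0-fold lower number from compound 3 to compound 4 (0.01 log units; within the scatter). Compound 4 is estimated at 235000 nM, with an expected range of 150000 nM to 270000 nM.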

Compound 4, solubility: > 250000 nM
Compound 4: a limit, no number (the forecaster's own chance of this, stated with the estimate: 10%); middle value at least 1.0-fold (0.02 log units) from the limit.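

In this assay, methoxy in place of hydrogen on a saturated chain carbon, six bonds along the chain from a nitrogen on an aromatic ring, gives an at least 1.0-fold higher number from compound 3 to compound 4 (0.01 log units; that floor lies within the scatter). Compound 4 gives > 250000 nM, which is a limit of the assay and not a number. The position therefore carries methoxy with the read-out still at the top of the assay's range, but the true size of the step cannot be read because compound 4 sits at a limit: the limit of > 250000 nM in this assay, at which 1 of the 4 values shown sits.

Going by these compounds, whether a hydroxy group or an amine on the same chain carbon, or a longer chain, keeps the read-out at this level remains open. Also open, on these data alone, is how methoxy at this place reads with nitro in place of carboxy, as in compound 2, which gives 1000 nM.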